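Chloro in Place of Sulfanyl: a Step Expected Within Scatter

The source may report more compounds than this note shows. Statements on the series, on what has been measured and on what is new or still open speak of the compounds shown alone.

Compound 2 `OC[C@H]1O[C@@H](n2cnc3c(S)nccc32)C[C@@H]1O` gives 10% in a functional assay (Homo sapiens) for inhibition of Nucleic Acid, tested at 100 uM; on this read-out higher numbers stand for more inhibition at the one concentration tested (going by the name of the read-out) and lower numbers for less inhibition. Of the two numbers measured it is the higher, yet compound 1 `[N-]=[N+]=Nc1nccc2c1ncn2[C@H]1C[C@H](O)[C@@H](CO)O1` with 4% lies within the scatter of it. Among the measured compounds shown here, the only step bearing on the same aromatic carbon was a number 6 percentage points higher from compound 1 to compound 2 (within the scatter), a small one. Compound 3 `OC[C@H]1O[C@@H](n2cnc3c(Cl)nccc32)C[C@@H]1O` differs from compound 2 by chloro in place of sulfanyl on an aromatic carbon. Given that one exchange at this carbon stayed within the scatter, the step of a number 2 percentage points lower from compound 2 to compound 3 (within the scatter) is expected to stay within the scatter as well, in no clear direction. Compound 3 is therefore estimated at 8%, between 0% and 22%.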

Compound 3, a percentage reported as inhibition, at one concentration (the size of the read-out at that concentration, not a potency): 5%
Compound 3: the middle estimate sits 3 percentage points above what was measured, within the range that was stated.
By their numbers in this assay, from the lowest: compounds 1, 3 and 2 (each within the scatter of the next).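

In this assay, chloro in place of sulfanyl gives a number 5 percentage points lower from compound 2 to compound 3 (within the scatter), and chloro in place of azido gives a number 1 percentage points higher from compound 1 to compound 3 (within the scatter). With three groups now compared on this aromatic carbon, all the steps among them stay within the scatter, so the change of group here separates none of the compounds. Nothing available explains these small steps. On these data alone, whether an amine or a longer chain on this same carbon would give a step beyond the scatter remains open.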